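From a Trifluoroethoxy Group to a Benzyl Group

The compounds below may be only part of what the source reports. "The series", "measured", "known", "first", "only" and "open" are said of these compounds alone.

Two compounds carry measured numbers. Compound 1 `COc1ccccc1N1CCN(CCCOc2ccccc2C(=O)N(C)C)CC1` gives in a functional assay for antagonist activity at Alpha-1A adrenergic receptor (Oryctolagus cuniculus) (on this read-out higher numbers stand for weaker binding and lower numbers for tighter binding), a value of 3.98 nM. Compound 2 `CN(C)C(=O)c1cccnc1NCCCN1CCN(c2ccccc2OCC(F)(F)F)CC1` gives in this assay a value of 0.1 nM, the lowest of the two numbers; its gap to compound 1 is beyond the usual scatter. Going by the values given here, no pair of measured compounds differs in one place only, so no single change has a measured step attached to it.

Compound 3 `CN(C)C(=O)c1cccnc1NCCCN1CCN(c2ccccc2Cc2ccccc2)CC1` has not been measured. It differs from compound 2 in one place: benzyl in place of 2,2,2-trifluoroethoxy on an aromatic carbon. What leaves carries one hydrogen-bond acceptor; what enters carries none and brings a ring.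

Among the compounds with values here, nothing among the measured compounds shows how this exchange moves the read-out, so the expectation rests on the structural change alone. The account therefore expects for compound 3 a value in this assay of 0.4 nM, with a range from 0.08 nM to 2.5 nM. That estimate means an expected step from compound 2 to compound 3 of a 4.0-fold higher number from compound 2 to compound 3 (0.60 log units; beyond the scatter), a modest loss that may still sit within the scatter.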

Compound 3, dissociation constant: 6.31 nM
The estimate for compound 3 lay 16-fold (1.20 log units) below the measured number, outside the stated range (above it).
By their numbers in this assay, from the lowest: compound 2; then compounds 1 and 3 (each within the scatter of the next).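

With the shared core held constant, the exchange of 2,2,2-trifluoroethoxy for benzyl on this aromatic carbon, ortho to a large group, now has a measured size in this assay: it gives a 63-fold higher number from compound 2 to compound 3 (1.80 log units; beyond the scatter), a large step towards weaker binding. Going by these compounds alone, this is the first single change with a measured step, and it shows that the read-out is far from indifferent to the group at this position, which the two earlier compounds, differing in more than one place, could not show. The exchange removes a group with one hydrogen-bond acceptor and no ring and installs one with no hydrogen-bond acceptor and a ring, but no measurement at hand bears on why the number moves as it does.

This one step cannot separate the loss of the acceptor from the arrival of the ring, and it does not show whether the exchange would move the number as far on the core of compound 1. Going by these compounds, whether an ethoxy group, which has no fluorine, or a phenoxy group, which keeps the oxygen and brings a ring, would hold this position near the number of compound 2 remains open.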